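A few compounds are considered here, and "the series" means these few. Any claim that something is new, unique, unknown or untested is made for them only; others in the source may bear on it.

Of the compounds shown here, three of one series have been measured in a functional assay on EA.hy 926 cells (Homo sapiens), read by fluorescence, tested at 10 uM; a higher number here means a stronger effect of the compound at the concentration tested, a lower number a weaker effect. Compound 1, `COc1cc(/C=C/C(=O)/C=C(/C=C/c2ccc(OC(C)=O)c(OC)c2)NC2CCCCC2)ccc1OC(C)=O`, gives 113%. Compound 2, `CCCNC(=C\C(=O)/C=C/c1ccc(O)c(OC)c1)/C=C/c1ccc(O)c(OC)c1`, gives 141%. Compound 3, `CCC(C)NC(=C\C(=O)/C=C/c1ccc(O)c(OC)c1)/C=C/c1ccc(O)c(OC)c1`, gives 184%, which is the highest of the three numbers; the nearest is compound 2, and the furthest is compound 1. Among the compounds with values here, the only single-point step among the measured compounds is a number 43 percentage points higher from compound 2 to compound 3 (beyond the scatter).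

Compound 4, `COc1cc(/C=C/C(=O)/C=C(/C=C/c2ccc(O)c(OC)c2)NC2CCCCC2)ccc1O`, has not yet been measured. It differs from compound 3 in one place: cyclohexyl in place of sec-butyl on an amine nitrogen. Compound 1 also carries cyclohexylamino, but it differs from compound 4 in further places, so its value only shows what a more distant relative gave.

Within the data shown here, the step that bears on this change is the one from compound 2 to compound 3, in which a larger group on the amine nitrogen went with a rise in this assay beyond the scatter. Cyclohexyl is again a larger group than sec-butyl at the same amine nitrogen. Compound 4 is therefore expected to hold or slightly exceed the level of compound 3, the expected step being a number 6 percentage points higher from compound 3 to compound 4 (within the scatter). The estimate for compound 4 is 190%, with a range from 145% to 235%.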

Compound 4, a percentage reported as activity, at one concentration (the size of the read-out at that concentration, not a potency): 191%
The estimate for compound 4 lay 1 percentage points below the measured number; low and high end bracket the measured number.
By their numbers in this assay, from the lowest: compound 1; then compound 2; then compounds 3 and 4 (each within the scatter of the next).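

In this assay the exchange of sec-butyl for cyclohexyl on the amine nitrogen gives a number 7 percentage points higher from compound 3 to compound 4 (within the scatter) and so the rise that came with the larger group in the earlier step does not carry on beyond the scatter here, and the six-membered ring of carbon only is accepted at this place at the level of sec-butyl. Measured against propyl, cyclohexyl gives a number 50 percentage points higher from compound 2 to compound 4 (beyond the scatter) and that step is of the same large kind as a number 43 percentage points higher from compound 2 to compound 3 (beyond the scatter) so among these three compounds with the free hydroxyl groups, propyl is the group that stands apart from the other two. No measurement shown accounts for these numbers.

From the compounds shown here alone, whether this level holds with a still larger ring such as cycloheptyl, with an aromatic group such as phenyl or benzyl, or with a cyclohexyl ring carrying a hydroxyl group or an amine remains open. The compounds shown also leave open whether the same picture would appear at concentrations other than the single one tested.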